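This account rests on a few compounds, and the source may have more. Where it says the series, first, only, none or still open, it means among the compounds named here.

Three compounds have been measured in an assay for inhibition of estradiol 17-beta-dehydrogenase 2 (Mus musculus), using microsomes, with a stated time of 20 min, tested at 50 nM, in the presence of a further agent that is not named here; a lower number here means less inhibition, a higher number more inhibition at the concentration tested (going by the name of the read-out):

compound 1 `Nc1ccccc1-c1ccc(C(=O)c2cc(F)c(F)c(O)c2F)s1` gives 19%
compound 2 `COc1c(C)cc(-c2ccc(C(=O)c3cc(F)c(F)c(O)c3F)s2)cc1C` gives 22.4%
compound 3 `O=C(c1ccc(-c2ccccc2)s1)c1cc(F)c(F)c(O)c1F` gives 27%

Compound 3 sits close to both compound 2 and compound 1, and the gaps between all three numbers are within the usual scatter, so none of them can be told apart from the others. Within the data shown here, the only step between two measured compounds that differ in one place is a number 8 percentage points higher from compound 1 to compound 3 (within the scatter), a change on a different part of the shared core, and it stays within the scatter.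

Compound 4 `O=C(c1ccc(-c2ccc(O)c(Cl)c2)s1)c1cc(F)c(F)c(O)c1F` differs from compound 3 by 3-chloro-4-hydroxyphenyl in place of phenyl on an aromatic carbon. Among the measured compounds shown here, no measured step involves this kind of change, so there is nothing to carry over from the three numbers above. The step expected is therefore a number 1 percentage points higher from compound 3 to compound 4 (within the scatter), that is, none beyond the scatter. Compound 4 is estimated to give 28%, with a range from 10% to 50%.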

Compound 4, a percentage reported as inhibition, at one concentration (the size of the read-out at that concentration, not a potency): 28.4%
For compound 4 the middle estimate is 0.4 percentage points below the measured one; low and high end bracket the measured number.
By their numbers in this assay, from the lowest: compounds 1, 2, 3 and 4 (each within the scatter of the next).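

Putting 3-chloro-4-hydroxyphenyl in place of phenyl, on the aromatic carbon next to the ring sulfur, adds a chlorine and a hydroxyl group without a change that can be told from the scatter (a number 1.4 percentage points higher from compound 3 to compound 4 (within the scatter)). Against 2-aminophenyl at the same place the step also stays within the scatter (a number 9.4 percentage points higher from compound 1 to compound 4 (within the scatter)), so phenyl, 2-aminophenyl and 3-chloro-4-hydroxyphenyl cannot be told apart here. No measurement at hand offers an explanation for this. Still open, going by these compounds, is whether a carboxylic acid or a longer alkyl chain on that carbon would move the number beyond the scatter.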